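Swapping a Hexyl Chain for a Fluorinated Benzyl Group

The compounds below may be only part of what the source reports. "The series", "measured", "known", "first", "only" and "open" are said of these compounds alone.

Measured compounds:
Compound 1 `CC(C(=O)NCc1ccc(C(C)(C)C)nc1N1CCC(Cc2ccccc2)CC1)c1ccc(NS(C)(=O)=O)c(F)c1`: 0.3 nM
Compound 2 `CCOc1nc(C(C)(C)C)ccc1CNC(=O)C(C)c1ccc(NS(C)(=O)=O)c(F)c1`: 14.8 nM
Compound 3 `CCCCCCOc1nc(C(C)(C)C)ccc1CNC(=O)C(C)c1ccc(NS(C)(=O)=O)c(F)c1`: 2.7 nM

All three were tested in an assay on cells for antagonist activity at transient receptor potential cation channel subfamily V member 1 (Homo sapiens), read by FLIPR and calcium flux, with a stated time of 6 min; on this read-out lower numbers stand for stronger inhibition and higher numbers for weaker inhibition. Compound 3 gives the second highest number of the three: it sits closest to compound 2, whose number is higher, and farthest from compound 1, whose number is lower. Compound 4 `CC(C(=O)NCc1ccc(C(C)(C)C)nc1OCc1ccc(F)cc1)c1ccc(NS(C)(=O)=O)c(F)c1` has not yet been measured. It differs from compound 3 in one place: 4-fluorophenyl in place of pentyl on a saturated chain carbon bound to an oxygen on an aromatic ring. Going by the values given here, only one measured step touches this position, the lengthening of the chain at the oxygen on the aromatic ring, a 5.5-fold lower number from compound 2 to compound 3 (0.74 log units; beyond the scatter). That step shows that a larger group at this place lowers the number. Among the compounds with values here, compound 4 keeps a group of similar size at the same place but replaces a chain with a ring, and no measured pair shows what that exchange does. A small step, if any, is therefore expected; the estimated step is a 1.4-fold lower number from compound 3 to compound 4 (0.13 log units; within the scatter). Compound 4 is expected to give about 2 nM in this assay, with a likely range from 0.5 nM to 8 nM.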

Compound 4, inhibition constant: 0.8 nM
Compound 4: the middle estimate sits 2.5-fold (0.40 log units) above what was measured, within the range that was stated.
By their numbers in this assay, from the lowest: compound 1; then compound 4; then compound 3; then compound 2.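

In this assay, going by these compounds alone, a ring at this position does more than match the chain: 4-fluorophenyl in place of pentyl gives a 3.4-fold lower number from compound 3 to compound 4 (0.53 log units; beyond the scatter), so swapping chain for ring, which no earlier pair covered, has a measurable effect. Set against the shorter chain, the same group gives a 19-fold lower number from compound 2 to compound 4 (1.27 log units; beyond the scatter), the largest step seen at this position so far. Nothing on hand explains why the group with the ring gives the lower number.

The compounds shown leave open what the fluorine itself contributes, a question that a plain benzyl group at this place would address. Also open, on these data alone, is how a pyridylmethyl group, which carries a nitrogen in its ring, would read in this assay.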